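The source may report more compounds than this note shows. Statements on the series, on what has been measured and on what is new or still open speak of the compounds shown alone.

Going by the values given here, in an ADME assay on the whole organism (Mus musculus, strain ICR) for pharmacokinetics, read by LC-MS, using cassette dosing, at a dose of 1 mg/kg by the oral route (on this read-out lower numbers stand for lower oral bioavailability and higher numbers for higher oral bioavailability), compound 1 `Cn1cc(C(=O)Nc2ccc3[nH]ncc3c2)c2ncc(-c3ccccc3)cc21` gives 39.3% and compound 2 `CCn1cc(C(=O)Nc2ccc3[nH]ncc3c2)c2ncc(-c3ccccc3)cc21` gives 57.7%, the higher of the two numbers so far. Compound 3 `CC(C)n1cc(C(=O)Nc2ccc3[nH]ncc3c2)c2ncc(-c3ccccc3)cc21` differs from compound 2 by methyl in place of hydrogen on a saturated chain carbon bound to an aromatic nitrogen and a saturated chain carbon, that is, ethyl to isopropyl. Among the compounds with values here, only one measured step bears on this, the related methyl-for-hydrogen change a number 18.4 percentage points higher from compound 1 to compound 2 (beyond the scatter). That single step is a weak guide, so a small upward move in this assay, perhaps none beyond the scatter, is expected. The estimated step is a number 4.3 percentage points higher from compound 2 to compound 3 (within the scatter). Compound 3 is expected at 62%, within a range of 42% to 80%.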

Compound 3, oral bioavailability in the Mus musculus assay: 59.8%
Beside the measured number, compound 3's estimate is 2.2 percentage points above it; the measured number falls inside the stated range.
By their numbers in the Mus musculus assay, from the lowest: compound 1; then compounds 2 and 3 (each within the scatter of the next).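

In the Mus musculus assay the branch on the saturated chain carbon adds nothing that can be read, a number 2.1 percentage points higher from compound 2 to compound 3 (within the scatter), although isopropyl keeps the gain over methyl on the aromatic nitrogen, a number 20.5 percentage points higher from compound 1 to compound 3 (beyond the scatter). In a physicochemical assay for solubility, read by HPLC, at pH 6.8 (a higher number here means a more soluble compound, a lower number a less soluble compound), the same ethyl to isopropyl change goes with a far wider separation: the measured solubility of compound 2, < 60 ug/mL, and of compound 3, 3200 ug/mL, an at least 53-fold higher number (1.72 log units; beyond the scatter)

In the physicochemical assay compound 2 gives < 60 ug/mL, a limit of the assay and not a number. In the physicochemical assay compound 3 gives 3200 ug/mL.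

Still open, going by these compounds, is how a longer chain or a cyclopropyl group on the aromatic nitrogen would read in either assay. On these data alone, the true size of the solubility step also stays open.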